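Benzyl to Phenyl on the Triazole of Compound 1

A few compounds are considered here, and "the series" means these few. Any claim that something is new, unique, unknown or untested is made for them only; others in the source may bear on it.

Compound 1 `O=C1O/C(=C\Cn2cc(Cc3ccccc3)nn2)C(OCc2ccccc2)=C1OCc1ccccc1` is one of three compounds tested in a functional assay on MCF7 cells (Homo sapiens) for antiproliferative activity, read by MTT assay, with a stated time of 24 h; on this read-out higher numbers stand for weaker inhibition and lower numbers for stronger inhibition. In this assay compound 1 gives 40000 nM, the higher of the two numbers recorded. Compound 2 `COC1=C(OC)C(O)(CCn2cc(-c3ccccc3)nn2)NC1=O` gives 22600 nM in this assay, a value that lies within the scatter of compound 1, so the two cannot be ordered. Compound 3 `CCCc1cn(CCC2(O)C(OCc3ccccc3)=C(OCc3ccccc3)C(=O)N2CCC)nn1` reached only a limit of the assay, > 100000 nM, which is the limit of > 100000 nM in this assay, at which 1 of the 3 values shown sits. Compound 4 `O=C1O/C(=C\Cn2cc(-c3ccccc3)nn2)C(OCc2ccccc2)=C1OCc1ccccc1` has not yet been measured; it differs from compound 1 by phenyl in place of benzyl on an aromatic carbon. Within the data shown here, no measured pair shows this change on its own, and compound 2, which carries a phenyl group on its triazole, gives 22600 nM, within the scatter of compound 1. The step of a 1.1-fold lower number from compound 1 to compound 4 (0.06 log units; within the scatter) is therefore expected to be none beyond the scatter. For compound 4 the estimate in this assay is 35000 nM, expected to fall between 15000 nM and 90000 nM.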

Compound 4, half-maximal inhibitory concentration: > 100000 nM
Compound 4 ended at the assay's limit; the forecaster's own chance of this, stated with the estimate: 10%; at least 2.8-fold (0.45 log units) between middle value and limit.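

In this assay, among these compounds, putting phenyl in place of benzyl on the aromatic carbon of the five-membered ring gives an at least 2.5-fold higher number from compound 1 to compound 4 (0.39 log units; beyond the scatter), and this is the first reading of the change on its own, as no earlier pair had isolated it. This position on the core of compound 1 is therefore not indifferent to the change: the phenyl form inhibits more weakly than the benzyl form, by a step beyond the usual scatter. Compound 4 stands at a limit of the assay rather than at a number: the limit of > 100000 nM in this assay, at which 2 of the 4 values shown sit.

On these data alone, the full size of the step stays open, as a limit gives only its lower bound. Also open, as far as these compounds go, is whether a longer chain such as phenylethyl in place of benzyl, or an amine on the aromatic ring, would give a lower number than compound 1.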